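The source may report more compounds than this note shows. Statements on the series, on what has been measured and on what is new or still open speak of the compounds shown alone.

In a functional assay on BGC-823 cells (Homo sapiens) for inhibition, read by MTT assay, with a stated time of 72 h (on this read-out lower numbers stand for stronger inhibition and higher numbers for weaker inhibition), compound 1 (`O=C1/C(=C\c2ccccc2)c2c(ncn2COCc2ccccc2)CCN1Cc1ccc(F)cc1`) gives 72900 nM and compound 2 (`Cc1cc(C)cc(CN2CCc3ncn(COCc4ccccc4)c3/C(=C/c3ccccc3)C2=O)c1`) gives 52600 nM. These two numbers lie within the scatter of each other, so the data do not set compound 2 apart from compound 1. Compound 3 (`O=C1/C(=C\c2ccccc2)c2c(ncn2COCc2ccccc2)CCN1Cc1ccc(-c2ccccc2)cc1`) keeps the shared core and differs from compound 2 only on a saturated chain carbon bound to an amide-type nitrogen in a ring: 4-phenylphenyl in place of 3,5-dimethylphenyl on a saturated chain carbon bound to an amide-type nitrogen in a ring. For the measured compounds named here, only one measured step bears on this place: a 1.4-fold lower number from compound 1 to compound 2 (0.14 log units; within the scatter), in which 3,5-dimethylphenyl took the place of 4-fluorophenyl. That step is a loose guide, since 4-phenylphenyl brings a second aromatic ring that neither measured compound has at this place. Going by the values given here, with only that step to go on, no clear shift is expected in this assay, and the estimated change is a 1.2-fold lower number from compound 2 to compound 3 (0.07 log units; within the scatter). Compound 3 is therefore expected to give about 45000 nM, with an estimated range from 15000 nM to 100000 nM.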

Compound 3, half-maximal inhibitory concentration: 81000 nM
Estimate against measurement, compound 3: 1.8-fold (0.26 log units) below; the measured number falls inside the stated range.
By their numbers in this assay, from the lowest: compounds 2, 1 and 3 (each within the scatter of the next).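

With compound 3, the group at this place grows from one aromatic ring to two, and in this assay the step is a 1.5-fold higher number from compound 2 to compound 3 (0.19 log units; within the scatter), which does not separate the two compounds. The step of a 1.1-fold higher number from compound 1 to compound 3 (0.05 log units; within the scatter), with phenyl in place of fluoro on an aromatic carbon, also lies within the scatter, so 4-fluorophenyl, 3,5-dimethylphenyl and 4-phenylphenyl cannot be told apart in this assay, even though the last adds a whole aromatic ring and the earlier pair alone could not test such an addition. No measured evidence is available that bears on this result.

All three compounds carry only carbon-based aromatic groups at this place, apart from the single fluoro, and all share the same core, so these data cannot show whether this place can shift the number beyond the scatter at all. From the compounds shown here alone, it remains open what an amine, a carboxylic acid or a pyridine ring would do here, or what a longer chain would do in place of the single saturated chain carbon bound to the amide-type nitrogen.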